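Notes on the amine-bearing side chain of the series

A few compounds are considered here, and "the series" means these few. Any claim that something is new, unique, unknown or untested is made for them only; others in the source may bear on it.

Of the compounds shown here, three of the shared core have been measured in a functional assay on A549 cells (Homo sapiens) for cytotoxicity, read by MTT assay, with a stated time of 72 h; a higher number here means a weaker inhibitor, a lower number a stronger inhibitor. Compound 1 `COc1cc2c(Oc3ccc(NC(=O)c4nnn(-c5ccccc5C)c4C)cc3F)ccnc2cc1OCCCN1CCCC1` gives 380 nM. Compound 2 `COc1cc2c(Oc3ccc(NC(=O)c4nnn(-c5ccccc5C)c4C)cc3F)ccnc2cc1OCCCN1CCCCC1` gives 330 nM. Compound 3 `COc1cc2c(Oc3ccc(NC(=O)c4nnn(-c5ccccc5C(F)(F)F)c4C)cc3F)ccnc2cc1OCCCN1CCCCC1` gives 170 nM. Among these three numbers compound 2 holds the second highest; the step of a 1.2-fold lower number from compound 1 to compound 2 (0.06 log units; within the scatter) and the step of a 1.9-fold lower number from compound 2 to compound 3 (0.29 log units; within the scatter) both stay within the scatter, so no order among the three can be claimed.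

Compound 4 `COc1cc2c(Oc3ccc(NC(=O)c4nnn(-c5ccccc5C)c4C)cc3F)ccnc2cc1OCCCN1CCC(C)CC1` is not yet measured. Against compound 2 the change is methyl in place of hydrogen on a saturated ring carbon. Of the measured steps, only a 1.2-fold lower number from compound 1 to compound 2 (0.06 log units; within the scatter) touches the same saturated ring, and it did not leave the scatter; the other, a 1.9-fold lower number from compound 2 to compound 3 (0.29 log units; within the scatter), lies elsewhere in the molecule and bears on this change only indirectly. Among the measured compounds shown here, no measured compound carries a methyl on this ring, so there is no direct precedent. A change of this size on the same ring is therefore expected to give no step beyond the scatter in this assay, that is no change at the digits printed from compound 2 to compound 4 (within the scatter). Compound 4 is estimated at 330 nM, with a range from 150 nM to 700 nM.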

Compound 4, half-maximal inhibitory concentration: 360 nM
Compound 4: middle estimate off by 1.1-fold (0.04 log units), on the low side; the range from low to high includes it.
By their numbers in this assay, from the lowest: compounds 3, 2, 4 and 1 (each within the scatter of the next, the first and the last beyond it).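

In this assay, methyl in place of hydrogen on the saturated ring, three ring bonds from the ring nitrogen, gives a 1.1-fold higher number from compound 2 to compound 4 (0.04 log units; within the scatter), so this first substitution on the ring itself leaves the read-out within the scatter. Read together with the ring exchange, a 1.1-fold lower number from compound 1 to compound 4 (0.02 log units; within the scatter) places pyrrolidin-1-yl, piperidin-1-yl and 4-methylpiperidin-1-yl within the scatter of one another on the core of compound 1, so the end of the side chain has so far tolerated each of these three amines without a resolvable step. No supporting measurement is available to explain this flat reading.

Still open, as far as these compounds go, is whether the flat reading extends to morpholin-4-yl, 4-methylpiperazin-1-yl or 4-hydroxypiperidin-1-yl at the end of the chain, or to a longer chain between the ring oxygen and the amine. Also open is whether 4-methylpiperidin-1-yl behaves the same way when paired with the trifluoromethyl group of compound 3, since the compounds shown do not combine the two changes.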